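Swapping a Ring on the Amine of a Kinase Inhibitor

The source may hold more compounds than are shown below. What is called first, only, known or untested is meant among the compounds shown, and "the series" means these compounds.

Compound 1: `N#Cc1cnc(NCc2cnccc2C(F)(F)F)cc1N[C@H]1CC[C@H](O)CC1`, 6500 nM
Compound 2: `N#Cc1cnc(NCc2cnccc2C(F)(F)F)cc1NC1CCOCC1`, 9800 nM

In an assay on isolated protein for inhibition of protein kinase C delta type (Homo sapiens), read by TR-FRET, with a stated time of 2 h (on this read-out lower numbers stand for stronger inhibition and higher numbers for weaker inhibition), compound 2 gives the highest of the two numbers shown, yet the only step that bears here, a 1.5-fold higher number from compound 1 to compound 2 (0.18 log units; within the scatter), stays within the scatter. Compound 3, `CC1(C)[C@H](Nc2cc(NCc3cnccc3C(F)(F)F)ncc2C#N)C[C@H]1C(N)=O`, carries a larger change at the same nitrogen: 3-carbamoyl-2,2-dimethylcyclobutyl in place of oxan-4-yl on a nitrogen on an aromatic ring. Within the data shown here, no measured step speaks to that group, so nothing beyond the scatter is expected in either direction. The estimate for compound 3 is 8000 nM, between 2500 nM and 25000 nM, which means a 1.2-fold lower number from compound 2 to compound 3 (0.09 log units; within the scatter) is expected.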

Compound 3, half-maximal inhibitory concentration: 900 nM
Beside the measured number, compound 3's estimate is 8.9-fold (0.95 log units) above it; the whole stated range lies above it.
By their numbers in this assay, from the lowest: compound 3; then compounds 1 and 2 (each within the scatter of the next).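

This nitrogen can move the number: in this assay there is an 11-fold lower number from compound 2 to compound 3 (1.04 log units; beyond the scatter) and a 7.2-fold lower number from compound 1 to compound 3 (0.86 log units; beyond the scatter) while the oxan-4-yl and 4-hydroxycyclohexyl groups of compound 2 and compound 1 stayed within the scatter of each other. Among these three compounds, only 3-carbamoyl-2,2-dimethylcyclobutyl stands apart. No measurement at hand explains the step.

The change replaces the ring and adds the carbamoyl and two methyl groups together, so the compounds shown cannot say which part matters. A cyclobutyl without the methyl groups, or one bearing a carboxylic acid or an amine instead of the carbamoyl, would help separate these parts.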